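Swapping an aminopiperidine for a methylsulfonylpiperazine on a cytotoxicity read-out

The source may hold more compounds than are shown below. What is called first, only, known or untested is meant among the compounds shown, and "the series" means these compounds.

Compound 1 `Cc1cc(/C=C/C#N)cc(C)c1Oc1nc(Nc2ccc(CN3CCNCC3)cc2)nc2ccsc12`: 3970 nM
Compound 2 `Cc1cc(/C=C/C#N)cc(C)c1Oc1nc(Nc2ccc(N3CCCC(N)C3)cc2)nc2ccsc12`: 3820 nM
Compound 3 `Cc1cc(/C=C/C#N)cc(C)c1Oc1nc(Nc2ccc(N3CCN(S(N)(=O)=O)CC3)cc2)nc2sccc12`: > 222000 nM

Of the compounds shown here, three that share the same core have been tested in an ADME assay on MT4 cells (Homo sapiens) for cytotoxicity, read by MTT assay, with a stated time of 5 days; on this read-out higher numbers stand for lower toxicity in this test and lower numbers for higher toxicity in this test. Compound 1 gives 3970 nM and compound 2 gives 3820 nM; the step of a 1.0-fold lower number from compound 1 to compound 2 (0.02 log units; within the scatter) is within the scatter, so the two are not told apart. Compound 3, which carries a sulfamoyl group on its piperazine, gives > 222000 nM, which is a limit of the assay rather than a number. Compound 2 thus stands at the lower of the two numbers, with compound 1 within the scatter beside it and the third result a limit.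

Compound 4 `Cc1cc(/C=C/C#N)cc(C)c1Oc1nc(Nc2ccc(N3CCN(S(C)(=O)=O)CC3)cc2)nc2ccsc12` differs from compound 2 in one place: 4-(methylsulfonyl)piperazin-1-yl in place of 3-aminopiperidin-1-yl on an aromatic carbon. Among the compounds with values here, no measured step covers this exact exchange; the one measured step, from compound 1 to compound 2, swaps two amine-bearing groups and stays within the scatter. Within the data shown here, the only compound bearing a sulfonyl group on the piperazine, compound 3, sits at the limit of > 222000 nM in this assay, at which 1 of the 3 values shown sits. By that comparison a sizeable rise is expected for compound 4, as the step of a 16-fold higher number from compound 2 to compound 4 (1.20 log units; beyond the scatter). The estimate for compound 4 in this assay is 60000 nM, with a range from 10000 nM to 300000 nM, and a real chance that only a limit is reported.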

Compound 4, half-maximal cytotoxic concentration: 11500 nM
Compound 4: the middle estimate sits 5.2-fold (0.72 log units) above what was measured, within the range that was stated.
By their numbers in this assay, from the lowest: compounds 2 and 1 (each within the scatter of the next); then compound 4. At a limit, above all of these: compound 3.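

At this position, on an aromatic carbon para to a large group, the read-out can move after all: in this assay, the exchange between the two amine-bearing groups stayed within the scatter, whereas 4-(methylsulfonyl)piperazin-1-yl gives a 3.0-fold higher number from compound 2 to compound 4 (0.48 log units; beyond the scatter). The comparison with the other amine-bearing group points the same way, with a 2.9-fold higher number from compound 1 to compound 4 (0.46 log units; beyond the scatter). Both steps are modest, so this change lowers toxicity in this test only to a limited degree, and it does so in the two pairs shown.

Compound 3 differs from compound 4 in more than one place and its result is a limit, not a number, so it cannot show how far this trend might extend: the limit of > 222000 nM in this assay, at which 1 of the 4 values shown sits A morpholine or a 4-acetylpiperazine in the same place would help separate the effect of the sulfonyl group from that of losing the free amine.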